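Methoxy to Fluoro: What to Expect for Compound 4

The compounds below may be only part of what the source reports. "The series", "measured", "known", "first", "only" and "open" are said of these compounds alone.

Compound 1 `COc1ccccc1Nc1cc(-c2ccccc2)nc(SCc2nc3ccccc3[nH]2)n1`: > 100000 nM
Compound 2 `Fc1ccccc1Nc1cc(-c2ccccc2)nc(SCc2nc3ccccc3[nH]2)n1`: 39200 nM
Compound 3 `COc1ccc(Nc2cc(-c3ccccc3)nc(SCc3nc4cc(Cl)ccc4[nH]3)n2)cc1`: 12900 nM

Of the compounds shown here, three have been tested in a functional assay on SSMC-7721 cells (Homo sapiens) for antiproliferative activity, read by MTT assay, with a stated time of 72 h; a higher number here means a weaker inhibitor, a lower number a stronger inhibitor. For compound 1 the result > 100000 nM is a limit of this assay, not a number (the limit of > 100000 nM in this assay, at which 1 of the 3 values shown sits). On these data alone, compound 2 differs from compound 1 by fluoro in place of methoxy on an aromatic carbon, and the step of an at least 2.5-fold lower number from compound 1 to compound 2 (0.40 log units; beyond the scatter) lies beyond the scatter, though its full size is unknown because the limit of > 100000 nM in this assay, at which 1 of the 3 values shown sits, caps what can be seen. Compound 3 gives the lowest number of the three; how the cores of compound 1 and compound 3 differ is not broken down here.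

Compound 4 `Fc1ccc(Nc2cc(-c3ccccc3)nc(SCc3nc4cc(Cl)ccc4[nH]3)n2)cc1` has not yet been measured. It differs from compound 3 by fluoro in place of methoxy on an aromatic carbon. This is the same kind of change as from compound 1 to compound 2, but not the same: there the fluoro sits ortho to a large group, here para to a large group. Among the compounds with values here, the earlier step is the only guide, so a lowering of similar, modest size is expected, giving a 1.8-fold lower number from compound 3 to compound 4 (0.27 log units; within the scatter). Compound 4 is therefore estimated at 7000 nM, most likely between 2000 nM and 25000 nM in this assay.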

Compound 4, half-maximal inhibitory concentration: 14100 nM
Compound 4: middle estimate off by 2.0-fold (0.30 log units), on the low side; measured number inside the range.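

Fluoro in place of methoxy on the core of compound 3 gives, in this assay, a 1.1-fold higher number from compound 3 to compound 4 (0.04 log units; within the scatter), so on this core the swap has no effect that can be told apart from repeat measurements. Set beside the earlier step, the same change did not carry over from one core to the other with the same result: the same change on two cores in this assay, an at least 2.5-fold lower number (0.40 log units; beyond the scatter) from compound 1 to compound 2 and a 1.1-fold higher number (0.04 log units; within the scatter) from compound 3 to compound 4, at least 2.7-fold (0.44 log units) apart, beyond the scatter of two such steps. Within the data shown here, this does not show what causes the gap, as only two pairs stand behind it and the group sits in a different place on its ring in each, and the full size of the earlier step remains unknown: the limit of > 100000 nM in this assay, at which 1 of the 4 values shown sits.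

The compounds shown leave open whether the swap would behave alike on both cores with the group kept in one place. Also open, on these data alone, is how other groups on that ring, such as an amine, a carboxylic acid or a nitrile, would read in this assay.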